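Ethyl on the ring nitrogen of compound 2: expected outcome

The compounds below may be only part of what the source reports. "The series", "measured", "known", "first", "only" and "open" are said of these compounds alone.

Compound 1 `CC[C@@H](C)Nc1nc(Cl)nc(N[C@@H](C)c2ccccc2)n1` and compound 2 `CCCNc1nc(Cl)nc(N[C@@H](C)c2ccccc2)n1` share one core and differ only at the chain carbon bound to the nitrogen on the aromatic ring. In an ADME assay on the whole organism for inhibition, with Echinochloa crus-galli var. formosensis as the target, with a stated time of 4 days (on this read-out lower numbers stand for stronger inhibition and higher numbers for weaker inhibition), compound 1 gives 7410 nM and compound 2 gives 15100 nM; the change is a 2.0-fold higher number from compound 1 to compound 2 (0.31 log units; beyond the scatter). Among the measured compounds shown here, on the two numbers in hand compound 2 has the higher one, with compound 1 as its only neighbour.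

Compound 3 `CCCN(CC)c1nc(Cl)nc(N[C@@H](C)c2ccccc2)n1` is not yet measured. Against compound 2 the difference is ethyl in place of hydrogen on a nitrogen on an aromatic ring, the propylamino becoming ethyl(propyl)amino. For the measured compounds named here, no measured pair varies this nitrogen; the only step known, from compound 1 to compound 2, concerns the chain carbon and is modest in size. The change into compound 3 sits elsewhere, so its direction cannot be read from that step, and a step of comparable size in either sense is the honest expectation. Compound 3 is therefore estimated at 22000 nM, in the range 7500 nM to 65000 nM, a step from compound 2 of a 1.5-fold higher number from compound 2 to compound 3 (0.16 log units; within the scatter).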

Compound 3, half-maximal inhibitory concentration: 282 nM
Compound 3: the middle estimate sits 78-fold (1.89 log units) above what was measured; the whole stated range lies above it.
By their numbers in this assay, from the lowest: compound 3; then compound 1; then compound 2.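

In this assay, the nitrogen on the aromatic ring responds far more strongly than the chain carbon: ethyl in place of hydrogen there gives a 54-fold lower number from compound 2 to compound 3 (1.73 log units; beyond the scatter), whereas the change at the chain carbon gave only a 2.0-fold higher number from compound 1 to compound 2 (0.31 log units; beyond the scatter). The branched (sec-butyl)amino group does not match this result, as ethyl(propyl)amino in its place gives a 26-fold lower number from compound 1 to compound 3 (1.42 log units; beyond the scatter), so among these three compounds the largest change comes with an ethyl on the nitrogen rather than with a methyl on the chain carbon. Nothing available accounts for the size of this step.

On these data alone, it remains open whether the effect is specific to ethyl or would also appear with a smaller methyl or a longer chain such as butyl on the same nitrogen. Also open, as far as these compounds go, is whether a methyl on the chain carbon would add to the effect of ethyl on the nitrogen, or whether the two changes would overlap when carried by a single compound.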